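Moving the fluorine on the saturated-ring phenyl of compound 3

This account rests on a few compounds, and the source may have more. Where it says the series, first, only, none or still open, it means among the compounds named here.

Compound 1, `NS(=O)(=O)c1ccc(N2N=C(c3ccc(Oc4ccccc4)cc3)CC2c2ccccc2F)cc1`: 96000 nM
Compound 2, `NS(=O)(=O)c1ccc(N2N=C(c3ccc(OCc4ccccc4)cc3)CC2c2ccccc2)cc1`: a limit only
Compound 3, `NS(=O)(=O)c1ccc(N2N=C(c3ccc(OCc4ccccc4)cc3)CC2c2ccc(F)cc2)cc1`: 90000 nM

In an ADME assay on Vero 76 cells (Chlorocebus sabaeus) for cytotoxicity, read by MTT assay, with a stated time of 96 h (a higher number here means that more compound is tolerated, a lower number that less compound is tolerated), compound 3 gives 90000 nM. Of the two numbers shown this is the lowest, but the nearest, compound 1 with 96000 nM, sits within the usual scatter, so the two cannot be told apart. Compound 2 yields only a limit in this assay, > 100000 nM; one of the three values sits at that limit (the limit of > 100000 nM in this assay, at which 1 of the 3 values shown sits).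

Compound 4, `NS(=O)(=O)c1ccc(N2N=C(c3ccc(OCc4ccccc4)cc3)CC2c2ccccc2F)cc1`, differs from compound 3 by 2-fluorophenyl in place of 4-fluorophenyl on a saturated ring carbon. Going by the values given here, the only measured step, an at least 1.1-fold lower number from compound 2 to compound 3 (0.04 log units; that floor lies within the scatter), concerns fluoro in place of hydrogen and lies within the scatter; it bears only loosely on a fluorine moved from one position of the ring to another. Compound 1 already carries a 2-fluorophenyl group and its value matches compound 3 within scatter. No step beyond the scatter is therefore expected for compound 4 in this assay, and compound 4 is estimated at 90000 nM, between 45000 nM and 180000 nM, a step of no change at the digits printed from compound 3 to compound 4 (within the scatter) from compound 3 being expected.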

Compound 4, half-maximal cytotoxic concentration: > 100000 nM
Compound 4 gave a limit, no number; the forecaster's own chance of this, stated with the estimate: 35%; middle value at least 1.1-fold (0.04 log units) from the limit.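

In this assay compound 4 reaches the limit of the assay, as compound 2 does, so 2-fluorophenyl on the saturated ring carbon leaves no readable sign of lower tolerance than 4-fluorophenyl. The move gives an at least 1.1-fold higher number from compound 3 to compound 4 (0.04 log units; that floor lies within the scatter), and benzyl in place of phenyl on the oxygen gives an at least 1.0-fold higher number from compound 1 to compound 4 (0.01 log units; that floor lies within the scatter); each is only a floor, so neither change is shown to exceed the scatter. The step from compound 2 to compound 4 cannot be read, since both values are limits: the limit of > 100000 nM in this assay, at which 2 of the 4 values shown sit.

On these data alone, the true values behind those limits remain open. So does whether an amine or a carboxylic acid in place of fluoro on the phenyl at the saturated ring carbon would give a step beyond the scatter.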